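This account rests on a few compounds, and the source may have more. Where it says the series, first, only, none or still open, it means among the compounds named here.

For the measured compounds named here, compound 1 `Cc1cc(C)c(NC(=O)N(Cc2cccc(-c3csc(C)n3)c2)C2CCCCCC2)c(C)c1` stands highest of the two numbers so far: in an assay on microsomes from intestine for inhibition of acyl-CoA:cholesterol acyltransferase (Oryctolagus cuniculus) (on this read-out higher numbers stand for weaker inhibition and lower numbers for stronger inhibition), compound 1 gives 180 nM. Compound 2 `O=C(Nc1c(F)cc(F)cc1F)N(Cc1ccc(-c2ccsc2)cc1)C1CCCCCC1` gives 23 nM in this assay, and the gap to compound 1 lies beyond the scatter. Compound 3 `Cc1cc(C)c(NC(=O)N(Cc2cccc(-c3cnn(C)c3)c2)C2CCCCCC2)c(C)c1` keeps the core of compound 1 and differs only in the change (1-methyl-1H-pyrazol-4-yl in place of 2-methyl-1,3-thiazol-4-yl on an aromatic carbon). Going by the values given here, no measured pair shows this exchange, so the direction is open. A step from compound 1 to compound 3 of a 1.4-fold higher number from compound 1 to compound 3 (0.14 log units; within the scatter) in this assay is expected, at most a modest weakening within or near the scatter. Compound 3 is therefore estimated at 250 nM, within 100 nM to 650 nM.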

Compound 3, half-maximal inhibitory concentration: 44 nM
Compound 3: the middle estimate sits 5.7-fold (0.75 log units) above what was measured, outside the stated range (below it).
By their numbers in this assay, from the lowest: compounds 2 and 3 (each within the scatter of the next); then compound 1.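

At the aromatic carbon meta to a large group, 1-methyl-1H-pyrazol-4-yl in place of 2-methyl-1,3-thiazol-4-yl gives a 4.1-fold lower number from compound 1 to compound 3 (0.61 log units; beyond the scatter) in this assay. This position therefore responds to the choice of five-membered aromatic ring, although both groups have the same heavy-atom, donor and acceptor counts. Nothing available accounts for the step.

Open, as far as these compounds go, is whether a pyridin-3-yl group or a carboxylic acid on this carbon would keep the number as low. Also open, from the compounds shown here alone, is whether the exchange gives a similar step when other parts of the core change.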